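The source may hold more compounds than are shown below. What is called first, only, known or untested is meant among the compounds shown, and "the series" means these compounds.

Compound 1 `CCS(=O)(=O)N(Cc1cn([C@@H]2O[C@H](COC(C)=O)[C@@H](OC(C)=O)[C@H]2OC(C)=O)nn1)c1ccc(Cl)cc1` — in a functional assay on RCC4 cells (Homo sapiens) for antiproliferative activity, read by XTT assay, with a stated time of 48 h (on this read-out higher numbers stand for weaker inhibition and lower numbers for stronger inhibition), compound 1 gives 250000 nM.
Compound 2 `COC(=O)CN(Cc1cn([C@@H]2O[C@H](COC(C)=O)[C@@H](OC(C)=O)[C@H](OC(C)=O)[C@H]2OC(C)=O)nn1)S(C)(=O)=O` — in this assay compound 2 gives > 250000 nM, which is a limit of the assay and not a number.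
Compound 3 `CCS(=O)(=O)N(Cc1cn([C@@H]2O[C@H](COC(C)=O)[C@@H](OC(C)=O)[C@H](OC(C)=O)[C@H]2OC(C)=O)nn1)c1ccc(Cl)cc1` — in this assay compound 3 gives > 250000 nM, again a limit of the assay rather than a number.

Going by these compounds, compound 3 therefore has no measured value of its own; it stands only at the limit of > 250000 nM in this assay, at which 2 of the 3 values shown sit, so its true position is unknown and could be anywhere past that edge. Among the three measured compounds, none has a step to another that can be counted, and the one plain number, that of compound 1, lies at the same edge.

Compound 4 `CC(=O)OC[C@H]1O[C@@H](n2cc(CN(c3ccc(Cl)cc3)S(=O)(=O)c3ccccc3)nn2)[C@H](OC(C)=O)[C@@H](OC(C)=O)[C@@H]1OC(C)=O` is built from compound 3 by a single exchange: phenyl in place of ethyl on a sulfonyl sulfur. Among the compounds with values here, no measured pair shows what such an exchange does, so there is no measured step to lean on.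

The expectation is that compound 4 stays near the same edge, with the step of a number no higher from compound 3 to compound 4 (the limit leaves the size open) expected to be no larger than the usual scatter. Compound 4 is estimated at 250000 nM, in a range from 60000 nM to 600000 nM, most likely reported again only as a limit.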

Compound 4, half-maximal inhibitory concentration: 115000 nM
Compound 4: middle estimate off by 2.2-fold (0.34 log units), on the high side; low and high end bracket the measured number.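

In this assay, phenyl in place of ethyl on a sulfonyl sulfur gives an at least 2.1-fold lower number from compound 3 to compound 4 (0.33 log units; beyond the scatter), so the group on this sulfur can change the read-out. For compound 3 the value is > 250000 nM, which is a limit of the assay and not a number, so the step has a known minimum but no known full size. The earlier compounds offered no step that could be counted, and their values stayed at the edge of the assay: the limit of > 250000 nM in this assay, at which 2 of the 4 values shown sit.

The compounds shown leave open whether the change in the number follows the aromatic ring itself or simply the larger carbon group, a question that a butyl chain or a benzyl group on the same sulfur would address. They also leave open what an amine or a carboxylic acid on the phenyl ring would do.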